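The source may hold more compounds than are shown below. What is called first, only, known or untested is meant among the compounds shown, and "the series" means these compounds.

Working notes on the series. Compound 1 `CNCCCNc1c(C(=O)NCc2ccc(F)cc2)nc(Br)c2cccnc12` gives 9000 nM in a functional assay on HCT-116 cells (Homo sapiens) for cytotoxicity, read by MTT assay, with a stated time of 72 h; a lower number here means a stronger inhibitor, a higher number a weaker inhibitor. Going by the values given here, of the two numbers available it is the higher: compound 3 `O=CNCCCCCCNc1nc(C(=O)NCc2ccc(F)cc2)c(O)c2ncccc12` gives 4000 nM in this assay, a gap beyond the usual scatter, but compound 3 differs from compound 1 in several places at once, so no single step is read from that pair. Compound 2 `O=C(NCCCNc1c(C(=O)NCc2ccc(F)cc2)nc(Br)c2cccnc12)c1ccccc1` returns only a limit of the assay, > 10000 nM in this assay. Among the compounds with values here, the one measured step on a single change, an at least 1.1-fold higher number from compound 1 to compound 2 (0.04 log units; that floor lies within the scatter), is consequently a floor rather than a number, since the limit of > 10000 nM in this assay, at which 1 of the 3 values shown sits, is where that value sits; it shows only that benzoyl in place of methyl on the amine nitrogen did not lower the number.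

The step followed here leads to compound 4 `Nc1cccc(Nc2c(C(=O)NCc3ccc(F)cc3)nc(Br)c3cccnc23)c1`, where (3-aminophenyl in place of 3-(methylamino)propyl on a nitrogen on an aromatic ring). Within the data shown here, the chain that carried the change from compound 1 to compound 2 leaves entirely, so that step bears on the present one only loosely, and no measured compound carries an aromatic group at this nitrogen. With a single related step that lies within the scatter, the expected step of no change at the digits printed from compound 1 to compound 4 (within the scatter) is one within the scatter, in no preferred direction. Compound 4 is therefore estimated at 9000 nM, with a range from 3000 nM to 27000 nM.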

Compound 4, half-maximal inhibitory concentration: > 10000 nM
Compound 4: only a limit was reported; the forecaster's own chance of this, stated with the estimate: 40%; middle value at least 1.1-fold (0.04 log units) away from the limit.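

Compound 4 returns only a limit of the assay in this assay, > 10000 nM. Read as a step, 3-aminophenyl in place of 3-(methylamino)propyl on a nitrogen on an aromatic ring gives an at least 1.1-fold higher number from compound 1 to compound 4 (0.04 log units; that floor lies within the scatter), so an aromatic group at this nitrogen, which none of the earlier compounds carried, did not lower the number. Benzoyl on the amine nitrogen of the chain and full replacement of the chain by 3-aminophenyl thus end at the same limit, and the upper end of the measurable range now holds both compound 2 and compound 4: the limit of > 10000 nM in this assay, at which 2 of the 4 values shown sit.

Going by these compounds, how far compound 2 and compound 4 lie past that limit remains unknown, so the two changes cannot be ranked against each other, and neither can be said to raise the number beyond the scatter. Also open, on these data alone, is whether a longer alkyl chain ending in a primary amine, or a phenyl group carrying a carboxylic acid in place of the amine, would move the number at this nitrogen in either direction.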